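The source may hold more compounds than are shown below. What is called first, only, known or untested is meant among the compounds shown, and "the series" means these compounds.

Three compounds built on a shared core were tested in a functional assay on the whole organism for inhibition, with Mus musculus as the target, with a stated time of 1 h, at a dose of 50 mg/kg by the oral route; on this read-out higher numbers stand for more inhibition at the one dose given (going by the name of the read-out) and lower numbers for less inhibition. Compound 1 `Cc1ccc(-c2c(S(=O)(=O)c3ccccc3)cnc3cc(C)nn23)cc1` gives 25.8% in this assay, compound 2 `Cc1cc2ncc(S(=O)(=O)c3ccccc3)c(-c3ccc(Br)cc3)n2n1` gives 7.4%, and compound 3 `Cc1ccc(-c2c(S(=O)(=O)c3ccccc3)cnc3cc(-c4ccc(Br)cc4)nn23)cc1` gives 74.1%, the highest of the three. Compound 1 differs from compound 2 by a single change, (methyl in place of bromo on an aromatic carbon), and this brought a number 18.4 percentage points higher from compound 2 to compound 1 (beyond the scatter). Compound 3 carries a 4-bromophenyl where compound 1 carries a methyl, and that gave a number 48.3 percentage points higher from compound 1 to compound 3 (beyond the scatter). Compound 4 `Cc1ccc(-c2cc3ncc(S(=O)(=O)c4ccccc4)c(-c4ccc(C)cc4)n3n2)cc1`, not yet measured, differs from compound 3 by methyl in place of bromo on an aromatic carbon, the same change as from compound 2 to compound 1; the difference between the cores of compound 2 and compound 3 is not broken down here. On that basis the step expected is a number 10.9 percentage points higher from compound 3 to compound 4 (beyond the scatter), which rests on a number 18.4 percentage points higher from compound 2 to compound 1 (beyond the scatter). Compound 4 is therefore estimated at 85%, with a likely range from 62% to 97%.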

Compound 4, a percentage reported as inhibition, in the whole organism at one dose (the size of the read-out at that dose, not a potency): 54.6%
Compound 4: the middle estimate sits 30.4 percentage points above what was measured; measured number below the stated range.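

On the core of compound 3, methyl in place of bromo gave a number 19.5 percentage points lower from compound 3 to compound 4 (beyond the scatter), so the direction of this change does not carry over from one core to the other: the same change on two cores in this assay, a number 18.4 percentage points higher (beyond the scatter) from compound 2 to compound 1 and a number 19.5 percentage points lower (beyond the scatter) from compound 3 to compound 4, 37.9 percentage points apart, beyond the scatter of two such steps. Separately, 4-methylphenyl in place of methyl gave a number 28.8 percentage points higher from compound 1 to compound 4 (beyond the scatter). These results do not show why the direction reverses, and two pairs of compounds set no rule for the wider series.

From the compounds shown here alone, it remains open how other groups would behave in the same place on this aromatic ring, for instance a methoxy group, an amine or a carboxylic acid. Going by these compounds, it also remains open whether any of them would give the same direction on both cores.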